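Chloro to bromo on the phenol core of compound 2

The compounds below may be only part of what the source reports. "The series", "measured", "known", "first", "only" and "open" are said of these compounds alone.

Among the compounds with values here, in a functional assay on MCF7 cells (Homo sapiens) for cytotoxicity, read by sulforhodamine B assay, with a stated time of 3 days (a higher number here means a weaker inhibitor, a lower number a stronger inhibitor), compound 2 `OCc1cc(O)cc(Cl)c1O` gives 14900 nM, the higher of the two numbers so far. Compound 1 `O=C1C(CO)=C[C@@H](O)[C@H]2O[C@@H]12` gives 5700 nM in this assay, and the gap between the two lies beyond the scatter. Compound 3 `OCc1cc(O)cc(Br)c1O` is not yet measured. It differs from compound 2 in one place: bromo in place of chloro on an aromatic carbon. Within the data shown here, no step between measured compounds covers this exchange, so the expectation rests on the change alone. The step of a 1.2-fold lower number from compound 2 to compound 3 (0.09 log units; within the scatter) is expected to be small, within the scatter, with no clear direction. Compound 3 is expected at 12000 nM, with a range from 5000 nM to 30000 nM.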

Compound 3, half-maximal inhibitory concentration: 8400 nM
Compound 3: middle estimate off by 1.4-fold (0.15 log units), on the high side; measured number inside the range.
By their numbers in this assay, from the lowest: compounds 1, 3 and 2 (each within the scatter of the next, the first and the last beyond it).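

Within the data shown here, a a 1.8-fold lower number from compound 2 to compound 3 (0.25 log units; within the scatter) in this assay gives the first direct reading at this position, ortho to a hydroxy group and meta to a hydroxymethyl group. Bromo in place of chloro on this aromatic carbon leaves compound 2 and compound 3 within the scatter of each other, so the exchange between these two halogens shows no clear effect on the number here. No supporting measurement bears on this result.

Open, on these data alone, is how an amine, a carboxylic acid or a methoxy group at this position would read. Also open, as far as these compounds go, is what replacing the hydroxymethyl group with a longer chain would do.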